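Shortening the alkoxy chain on the aminoquinoline core

A few compounds are considered here, and "the series" means these few. Any claim that something is new, unique, unknown or untested is made for them only; others in the source may bear on it.

Compound 1 `COCCOCCOc1cccc2ccc(N)nc12` gives, in an assay on cells with melanin-concentrating hormone receptor 1 (Homo sapiens) as the target, read by radioligand binding (a lower number here means a stronger inhibitor, a higher number a weaker inhibitor), a value of > 2000 nM, which is a limit of the assay rather than a number.
Compound 2 `CCCC(C)Oc1cccc2ccc(N)nc12` gives 105 nM in this assay.
Compound 3 `CC#CCCOc1cccc2ccc(N)nc12` gives > 2000 nM in this assay, again a limit and not a number.

Compound 3 thus sits at the limit of the assay, and the limit of > 2000 nM in this assay, at which 2 of the 3 values shown sit, shows that it shares this position with compound 1; only compound 2 returns a measured number. The step to compound 4 `CCCOc1cccc2ccc(N)nc12` is methyl in place of prop-1-yn-1-yl on a saturated chain carbon, two bonds along the chain from an oxygen on an aromatic ring. Among the measured compounds shown here, two measured steps touch the same part of the structure. The step that the two limits leave unreadable from compound 1 to compound 3 cannot be read, as both ends are limits. The step of an at least 19-fold higher number from compound 2 to compound 3 (1.27 log units; beyond the scatter) shows that replacing the branched chain of compound 2 with the alkyne-bearing chain of compound 3 costs a great deal. Compound 4 carries neither the branching of compound 2 nor the triple bond of compound 3, so the direction of the change in this assay is expected to be toward a lower number than the limit of compound 3, with the size uncertain; the estimated step is an at least 2.5-fold lower number from compound 3 to compound 4 (0.39 log units; beyond the scatter). Compound 4 is therefore estimated at 800 nM, within the range 150 nM to 3000 nM.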

Compound 4, half-maximal inhibitory concentration: 1100 nM
For compound 4 the middle estimate is 1.4-fold (0.14 log units) below the measured one; the range from low to high includes it.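

Among the unbranched chains shown, only compound 4, with its propyl chain, returns a measured number in this assay rather than a limit: the limit of > 2000 nM in this assay, at which 2 of the 4 values shown sit.

Replacing the prop-1-yn-1-yl end with methyl gives an at least 1.8-fold lower number from compound 3 to compound 4 (0.25 log units; that floor lies within the scatter), and replacing the 2-methoxyethoxy end with methyl gives an at least 1.8-fold lower number from compound 1 to compound 4 (0.25 log units; that floor lies within the scatter), so neither step on its own establishes a real gain, even though compound 4 is the only one of the three with a measured number. The chain on the oxygen still matters a great deal once a number is available on both sides, as propyl in place of 1-methylbutyl gives a 10-fold higher number from compound 2 to compound 4 (1.02 log units; beyond the scatter), and losing the triple bond therefore does not bring compound 4 to the level of compound 2.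

That last step changes chain length and branching together, so the compounds shown cannot separate the two; an unbranched pentyl chain or a branched isopropyl chain on the same oxygen would divide them. Going by these compounds, how far compound 1 and compound 3 lie beyond their limits also stays open, and with it the true size of both steps to compound 4.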